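A few compounds are considered here, and "the series" means these few. Any claim that something is new, unique, unknown or untested is made for them only; others in the source may bear on it.

Measured in a functional assay on the whole organism with Rattus norvegicus as the target, with a stated time of 4 h, at a dose of 40 mg/kg by the intraperitoneal route; a higher number here means more inhibition at the dose given (going by the name of the read-out), a lower number less inhibition:
compound 1, `COCc1c(C)nc2c(OCc3ccccc3)cccn12`, 99%
compound 2, `Cc1nc2c(OCc3ccccc3)cccn2c1Br`, 26%

Among the measured compounds shown here, compound 2 stands lowest of the two numbers in this assay; its only neighbour is compound 1, separated by a number 73 percentage points lower from compound 1 to compound 2 (beyond the scatter). Compound 3, `Cc1nc2c(OCc3ccccc3)cccn2c1CC(=O)O`, differs from compound 2 in one place: carboxymethyl in place of bromo on an aromatic carbon. For the measured compounds named here, no measured step exchanges bromo for carboxymethyl, so nothing bears directly on this change. Going by the values given here, the single step on record, a number 73 percentage points lower from compound 1 to compound 2 (beyond the scatter), alters the same position and shows how far the read-out can move when the group there is exchanged. The entering carboxymethyl is not the methoxymethyl of compound 1, so the direction rests on the two values alone. Because compound 1 reaches 99% with a substituted carbon at this position, a step upward in this assay is expected, of uncertain size, a number 34 percentage points higher from compound 2 to compound 3 (beyond the scatter). For compound 3 the estimate is 60%, with a range from 20% to 95%.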

Compound 3, a percentage reported as inhibition, in the whole organism at one dose (the size of the read-out at that dose, not a potency): 12%
Estimate against measurement, compound 3: 48 percentage points above; measured number outside the range, below it.
By their numbers in this assay, from the lowest: compound 3; then compound 2; then compound 1.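

A carbon substituent at this position does not by itself carry the high read-out in this assay: carboxymethyl in place of bromo gives no recovery towards compound 1 but a further drop (a number 14 percentage points lower from compound 2 to compound 3 (beyond the scatter)). The saturated chain carbon bound to the aromatic carbon is common to compound 1 and compound 3, so the largest step in the series (a number 87 percentage points lower from compound 1 to compound 3 (beyond the scatter)) goes with carboxy in place of methoxy on that carbon, and compound 3 stands lowest of the three. No measurement on hand accounts for either step.

Still open, as far as these compounds go, is how hydroxymethyl, aminomethyl, a methyl ester of the carboxylic acid or a longer ether chain would read at this position. From the compounds shown here alone, whether plain methyl or ethyl here comes close to compound 1 also remains open.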